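Adding a Fluorine to the Phenyl Ring of Compound 2

The compounds below may be only part of what the source reports. "The series", "measured", "known", "first", "only" and "open" are said of these compounds alone.

Among the measured compounds shown here, compound 2 `CCOC(=O)Nc1cccc2c1CN(C)CC2c1ccccc1` shows the lowest number measured so far in a functional assay on the whole organism for inhibition of sodium-dependent dopamine transporter (Mus musculus) (a higher number here means that more compound is needed for the effect, a lower number that less compound is needed), where compound 2 gives 2.5 mg/kg. Its nearest neighbour, compound 1 `CCCCNC(=O)Nc1cccc2c1CN(C)CC2c1ccccc1`, gives 69 mg/kg in this assay. For the measured compounds named here, the only measured step, a 28-fold lower number from compound 1 to compound 2 (1.44 log units; beyond the scatter), concerns the group on the carbonyl carbon and says nothing about the phenyl ring that changes here. Compound 3 `CCOC(=O)Nc1cccc2c1CN(C)CC2c1ccc(F)cc1` differs from compound 2 in one place: fluoro in place of hydrogen on an aromatic carbon. Going by the values given here, no measured step bears on this ring, so the numbers give no direction for such a change in this assay. The expectation is therefore a step of no change at the digits printed from compound 2 to compound 3 (within the scatter), which is a change no larger than the usual scatter of repeated measurements. Compound 3 is estimated to give 2.5 mg/kg in this assay, with a range from 1 mg/kg to 6.3 mg/kg.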

Compound 3, dose for half-maximal effect: 4.6 mg/kg
Compound 3: middle estimate off by 1.8-fold (0.26 log units), on the low side; the measured number falls inside the stated range.
By their numbers in this assay, from the lowest: compounds 2 and 3 (each within the scatter of the next); then compound 1.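

Fluoro in place of hydrogen, para to a large group, gives a 1.8-fold higher number from compound 2 to compound 3 (0.26 log units; within the scatter) in this assay, so the two numbers cannot be told apart. Among the compounds shown here, this is the first measured sign that the phenyl ring of the core accepts this small change at this position, whereas the only earlier step, a 28-fold lower number from compound 1 to compound 2 (1.44 log units; beyond the scatter), concerned the group on the carbonyl carbon. Nothing measured alongside these numbers offers an explanation for this result.

One fluorine at one position cannot show how much room for change this place allows, and a larger group such as chloro, methoxy or trifluoromethyl could behave quite differently. Also open, on these data alone, is whether a fluoro elsewhere on the phenyl ring, or an amine or carboxylic acid at this same position, would keep the number within the scatter of compound 2.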